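A Larger Amine on the Carbonyl Carbon

The source may hold more compounds than are shown below. What is called first, only, known or untested is meant among the compounds shown, and "the series" means these compounds.

Compound 1 `COc1cc2c(cc1OC)C(CC(=O)N(C)C)CC2` gives 23.3% in a functional assay on the whole organism (strain Wistar) for inhibition, with Rattus norvegicus as the target, read by paw edema, with stated times of 60 min and 24 h, at a dose of 100 mg/kg by the oral route; a higher number here means more inhibition at the dose given (going by the name of the read-out), a lower number less inhibition. Of the two numbers shown, its result is set apart from that of compound 2 `CCCNC(=O)CC1CCc2cc(OC)c(OC)cc21`, which gives 26.7%, only by a number 3.4 percentage points higher from compound 1 to compound 2 (within the scatter), a gap within the scatter. Compound 3 `COc1cc2c(cc1OC)C(CC(=O)N1CCCCC1)CC2` differs from compound 1 in one place: piperidin-1-yl in place of dimethylamino on a carbonyl carbon. Among the compounds with values here, the single measured step at this carbonyl carbon, from compound 1 to compound 2, was small, so the exchange in compound 3 is expected to bring no shift beyond the scatter in this assay, with a number 1.7 percentage points higher from compound 1 to compound 3 (within the scatter). Compound 3 is therefore estimated at 25%, ranging from 10% to 40%.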

Compound 3, a percentage reported as inhibition, in the whole organism at one dose (the size of the read-out at that dose, not a potency): 40%
Compound 3: middle estimate off by 15 percentage points, on the low side; low and high end bracket the measured number.
By their numbers in this assay, from the lowest: compounds 1 and 2 (each within the scatter of the next); then compound 3.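

Piperidin-1-yl on the carbonyl carbon stands apart in this assay with a number 16.7 percentage points higher from compound 1 to compound 3 (beyond the scatter) and with a number 13.3 percentage points higher from compound 2 to compound 3 (beyond the scatter) so this position does respond to the group it carries, which the earlier step, within the scatter, did not show. Of the three compounds, the one with a ring at this place is the one set apart, while dimethylamino and propylamino are not set apart from each other. Nothing at hand gives a reason for this.

From the compounds shown here alone, whether the ring or simply the larger group counts remains open. Pyrrolidin-1-yl, morpholin-4-yl or an open-chain dibutylamino on the same carbonyl carbon would bear on that question.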